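A few compounds are considered here, and "the series" means these few. Any claim that something is new, unique, unknown or untested is made for them only; others in the source may bear on it.

Among the compounds with values here, in an ADME assay on a cell-free system (plasma, Homo sapiens) for metabolic stability, read by LC-MS (a lower number here means that the compound disappears faster, a higher number that the compound lasts longer), compound 2 `CC(C)OCCOC(=O)c1cccc(-c2cc(C(=O)Nc3ccncc3F)ccc2CN)c1` gives 0.1 h, the only actual number so far. Compound 1 `NCc1ccc(C(=O)Nc2ccncc2F)cc1-c1cccc(C(=O)OCC2CCCO2)c1` gives < 0.0834 h, which is a limit and not a number. The other measured value thus sits at the limit of < 0.0834 h in this assay, at which 1 of the 2 values shown sits, and compound 2 has no second number to be ranked against.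

Compound 3 `NCc1ccc(C(=O)Nc2ccncc2F)cc1-c1cccc(C(=O)OCCO)c1` carries hydrogen in place of isopropyl on an oxygen on a saturated carbon, which turns 2-isopropoxyethyl into 2-hydroxyethyl.

Within the data shown here, only one measured step bears on this change: an at least 1.1-fold higher number from compound 1 to compound 2 (0.07 log units; that floor lies within the scatter), an exchange within the same chain. It sets only a floor, so it offers no measured size to carry over, and no step beyond the scatter is expected in this assay.

The estimated step is a 1.2-fold higher number from compound 2 to compound 3 (0.08 log units; within the scatter). For compound 3 the expected half-life is 0.12 h, with an estimated range of 0.07 h to 0.3 h.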

Compound 3, half-life: 1.35 h
The estimate for compound 3 lay 11-fold (1.05 log units) below the measured number; the measured number lies above the stated range.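

In this assay, the end of this chain proves to matter: hydrogen in place of isopropyl on an oxygen on a saturated carbon gives a 14-fold higher number from compound 2 to compound 3 (1.13 log units; beyond the scatter). Hydroxymethyl in place of oxolan-2-yl at the corresponding place gives an at least 16-fold higher number from compound 1 to compound 3 (1.20 log units; beyond the scatter), so among these three compounds 2-hydroxyethyl alone stands clear of the others, whereas the earlier comparison gave only a floor within the scatter. The value of compound 1 is a limit and not a number: the limit of < 0.0834 h in this assay, at which 1 of the 3 values shown sits.

Still open, on these data alone, is whether the step belongs to the hydroxy group itself or to the loss of isopropyl, which a 2-methoxyethyl or 2-aminoethyl group in the same place would help to separate. Also open, as far as these compounds go, is whether a longer chain ending in hydroxy would keep the longer half-life.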